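A few compounds are considered here, and "the series" means these few. Any claim that something is new, unique, unknown or untested is made for them only; others in the source may bear on it.

Three compounds have been measured in a functional assay on A549 cells (Homo sapiens) for cytotoxicity, read by MTT assay, with a stated time of 72 h; on this read-out lower numbers stand for stronger inhibition and higher numbers for weaker inhibition:

Compound 1 `O=C(Nc1ccc(Oc2ccnc3[nH]ccc23)cc1)c1nn(-c2ccc(Br)cc2)ccc1=O` gives 6240 nM.
Compound 2 `Cn1ccc2c(Oc3ccc(NC(=O)c4nn(-c5ccc(Br)cc5)ccc4=O)cc3)ccnc21` gives 59400 nM.
Compound 3 `Cc1cc(=O)n(-c2ccccc2OC(F)(F)F)nc1C(=O)Nc1ccc(Oc2ncnc3[nH]ccc23)cc1` gives 16200 nM.

Compound 1 and compound 2 differ in a single place, (methyl in place of hydrogen on an aromatic nitrogen). That one change moved the read-out by a clear margin, a 9.5-fold higher number from compound 1 to compound 2 (0.98 log units; beyond the scatter), so a small added group at that nitrogen weakened the effect on the cells well beyond the usual scatter. Compound 3 carries a different core from compound 1; the difference between the two cores is not broken down here. Its own number in this assay sits between those of compound 1 and compound 2, with both gaps beyond the scatter.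

Compound 4 `Cc1cc(=O)n(-c2ccccc2OC(F)(F)F)nc1C(=O)Nc1ccc(Oc2ncnc3c2ccn3C)cc1` is compound 3 with the same change that turned compound 1 into compound 2: methyl in place of hydrogen on an aromatic nitrogen. Since both the group that leaves, the group that enters and the place are the same, the step from compound 3 to compound 4 is expected to be of a similar size, a 7.4-fold higher number from compound 3 to compound 4 (0.87 log units; beyond the scatter), resting on the measured step of a 9.5-fold higher number from compound 1 to compound 2 (0.98 log units; beyond the scatter). Compound 4 is therefore estimated to give about 120000 nM in this assay, most likely between 40000 nM and 400000 nM.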

Compound 4, half-maximal inhibitory concentration: 25200 nM
Compound 4: the middle estimate sits 4.8-fold (0.68 log units) above what was measured; measured number below the stated range.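

The same methyl on the aromatic nitrogen did not have the same effect on both cores in this assay. On the core of compound 3 the step is a 1.6-fold higher number from compound 3 to compound 4 (0.19 log units; within the scatter), which cannot be told apart from no effect, and it does not match the earlier step: the same change on two cores in this assay, a 9.5-fold higher number (0.98 log units; beyond the scatter) from compound 1 to compound 2 and a 1.6-fold higher number (0.19 log units; within the scatter) from compound 3 to compound 4, 6.1-fold (0.79 log units) apart, beyond the scatter of two such steps. So the size of the step measured on compound 1 and compound 2 did not carry over to this second core, but two pairs cannot show why, or predict the step on any further core.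

Compound 1 and compound 3 differ in more than one place, so the compounds shown leave open which of those differences sets the size of the step. They also leave open whether an ethyl group, a longer chain or a chain ending in an amine on that nitrogen would follow the methyl on either core.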